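This account rests on a few compounds, and the source may have more. Where it says the series, first, only, none or still open, it means among the compounds named here.

Measured compounds:
- compound 1, `O=C1/C(=C/c2ccccc2)C=C(c2ccc(Cl)cc2)N1Cc1ccccc1`, 24%
- compound 2, `O=C1/C(=C/c2ccc(Cl)cc2)C=C(c2ccc(Cl)cc2)N1Cc1ccccc1`, 58.7%
- compound 3, `O=C1/C(=C/c2ccc([N+](=O)[O-])cc2)C=C(c2ccc(Cl)cc2)N1Cc1ccccc1`, 12%

All three share one core and differ only in the group on the aromatic ring that hangs off the double bond. In a functional assay on the whole organism (strain Wistar) for inhibition, with Rattus norvegicus as the target, with stated times of 30 min and 2 h, at a dose of 20 mg/kg by the oral route (on this read-out lower numbers stand for less inhibition and higher numbers for more inhibition at the one dose given (going by the name of the read-out)), compound 3 stands lowest of the three: its nearest neighbour is compound 1, and the step of a number 12 percentage points lower from compound 1 to compound 3 (beyond the scatter) went with nitro in place of hydrogen. The widest gap is to compound 2, where the step of a number 46.7 percentage points lower from compound 2 to compound 3 (beyond the scatter) went with nitro in place of chloro. In the other direction, the step of a number 34.7 percentage points higher from compound 1 to compound 2 (beyond the scatter) shows that a chloro on this aromatic carbon gave a large gain over hydrogen.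

Compound 4 is `O=C1/C(=C/c2ccc(F)cc2)C=C(c2ccc(Cl)cc2)N1Cc1ccccc1`. It differs from compound 3 only here: fluoro in place of nitro on an aromatic carbon, that is, 4-nitrophenyl becomes 4-fluorophenyl. The steps bearing on this are those from compound 2 and compound 1 to compound 3, both beyond the scatter and both pointing the same way: removing the nitro should raise the number. Fluoro, like chloro, is a halogen, but no halogen other than chloro has been measured, so the expected gain is placed between the hydrogen and chloro cases. Compound 4 is therefore expected to give 38%, within 18% to 60%, an expected rise of a number 26 percentage points higher from compound 3 to compound 4 (beyond the scatter) in this assay.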

Compound 4, a percentage reported as inhibition, in the whole organism at one dose (the size of the read-out at that dose, not a potency): 58.7%
Estimate against measurement, compound 4: 20.7 percentage points below; measured number inside the range.
By their numbers in this assay, from the lowest: compound 3; then compound 1; then compounds 2 and 4 (each within the scatter of the next).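

In this assay, fluoro on this aromatic carbon reads the same as chloro (no change at the digits printed from compound 2 to compound 4 (within the scatter)), so the high number seen with compound 2 is not tied to chloro alone. Fluoro also stands clear of hydrogen (a number 34.7 percentage points higher from compound 1 to compound 4 (beyond the scatter)) and of nitro (a number 46.7 percentage points higher from compound 3 to compound 4 (beyond the scatter)), which places the two halogen compounds together above compound 1, with compound 3 lowest of the four. Nothing available here explains why the two halogens read alike or why nitro reads lowest.

From the compounds shown here alone, it remains open whether bromo or iodo on the same carbon would keep the number this high, and what an amine or a methoxy group would give there. Also open, going by these compounds, is whether fluoro and chloro would still read alike on a different carbon of this ring.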